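The source may hold more compounds than are shown below. What is called first, only, known or untested is meant among the compounds shown, and "the series" means these compounds.

Measured set in an ADME assay on MRC5 cells (Homo sapiens) for inhibition, with a stated time of 72 h; on this read-out lower numbers stand for an effect already at smaller amounts and higher numbers for an effect only at larger amounts of compound:
compound 1 `COc1cccc(OC)c1C(=O)Nc1c[nH]nc1C(=O)N[C@H]1CC[C@H](OC)CC1` gives 31000 nM
compound 2 `COc1ccccc1C(=O)Nc1c[nH]nc1C(=O)N[C@H]1CC[C@H](OC)CC1` gives 1500 nM
compound 3 `CO[C@H]1CC[C@H](NC(=O)c2n[nH]cc2NC(=O)c2cc3ccccn3n2)CC1` gives 1000 nM

Compound 1 stands at the highest number of the three. Its nearest neighbour is compound 2, reached by a 21-fold lower number from compound 1 to compound 2 (1.32 log units; beyond the scatter), the change being hydrogen in place of methoxy on an aromatic carbon. Compound 3 follows with a 1.5-fold lower number from compound 2 to compound 3 (0.18 log units; within the scatter), a change at the carbonyl carbon on the other side of the shared core, within the scatter.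

Compound 4 `COCCNC(=O)c1n[nH]cc1NC(=O)c1c(OC)cccc1OC` keeps both methoxy groups of compound 1 and alters only the amide side: 2-methoxyethyl in place of 4-methoxycyclohexyl on an amide-type nitrogen. For the measured compounds named here, none of the measured steps touches this position; both known steps change the acyl part while the (4-methoxycyclohexyl)amino group is held constant in every measured compound. Going by the values given here, there is therefore no step in this set from which a direction for the 4-methoxycyclohexyl to 2-methoxyethyl exchange could be read, and the working expectation is a step of no more than the scatter, with the uncertainty widened in both directions for the lack of any precedent.

Estimate: compound 4 is expected to give 30000 nM in this assay, range 8000 nM to 100000 nM, meaning an expected step of a 1.0-fold lower number from compound 1 to compound 4 (0.01 log units; within the scatter) from compound 1.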

Compound 4, half-maximal effective concentration: > 50000 nM
Compound 4: no number, only a limit; the forecaster's own chance of this, stated with the estimate: 25%; middle value at least 1.6-fold (0.22 log units) from the limit.
By their numbers in this assay, from the lowest: compounds 3 and 2 (each within the scatter of the next); then compound 1. At a limit, above all of these: compound 4.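

In this assay, for the compounds shown here, the group on the amide-type nitrogen changes for the first time, and 2-methoxyethyl in place of 4-methoxycyclohexyl gives an at least 1.6-fold higher number from compound 1 to compound 4 (0.20 log units; that floor lies within the scatter). Compound 4 gives > 50000 nM, which is a limit of the assay and not a number. With both methoxy groups of compound 1 kept, this exchange therefore gives no lower number, but only a floor for the step is known, so neither a real rise nor its size can be read, and the reading stops at the assay's limit: the limit of > 50000 nM in this assay, at which 1 of the 4 values shown sits.

On these data alone, it remains open whether the same exchange would give a readable step on the acyl parts of compound 2 or compound 3, whose numbers in this assay lie well away from that limit, and a pair of that kind would separate the effect of this position from that of the acyl part. Also open, as far as these compounds go, is how the number responds at the amide-type nitrogen to a plain cyclohexyl without the methoxy group, to a longer chain, or to a chain ending in an amine or a carboxylic acid.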